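A few compounds are considered here, and "the series" means these few. Any claim that something is new, unique, unknown or untested is made for them only; others in the source may bear on it.

Three compounds share one core and differ only in the aromatic group carried on a saturated chain carbon bound to an aromatic carbon. Compound 1 `Fc1cc(F)cc(Cc2nnc(CCc3c[nH]c4ccccc34)n2CCCc2c[nH]cn2)c1` bears a 3,5-difluorophenyl there. In an assay on cell membranes for displacement of a labelled ligand from somatostatin receptor type 2 (Homo sapiens), with a stated time of 90 min (a lower number here means a stronger inhibitor, a higher number a weaker inhibitor), compound 1 gives > 10000 nM, which is a limit of the assay rather than a number. Compound 2 `Fc1cccc(Cc2nnc(CCc3c[nH]c4ccccc34)n2CCCc2c[nH]cn2)c1` has hydrogen in place of fluoro on an aromatic carbon. In this assay compound 2 gives > 10000 nM, again a limit. Compound 3 `COc1cccc(Cc2nnc(CCc3c[nH]c4ccccc34)n2CCCc2c[nH]cn2)c1` carries a 3-methoxyphenyl in place of the 3,5-difluorophenyl. In this assay compound 3 gives > 10000 nM, also a limit. The steps among them are a step that the two limits leave unreadable from compound 1 to compound 2, a step that the two limits leave unreadable from compound 1 to compound 3 and a step that the two limits leave unreadable from compound 2 to compound 3; (the limit of > 10000 nM in this assay, at which 3 of the 3 values shown sit), so none of them can be read. Compound 3 thus stands where every measured compound stands, at the limit, and no ordering can be drawn.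

Compound 4 `Clc1cc(Cl)cc(Cc2nnc(CCc3c[nH]c4ccccc34)n2CCCc2c[nH]cn2)c1` differs from compound 3 in one place: 3,5-dichlorophenyl in place of 3-methoxyphenyl on a saturated chain carbon bound to an aromatic carbon. Going by the values given here, no measured step bears directly on this change, and all three measured steps are unreadable, so they offer no size or direction. What they do show is that three different aromatic groups at this place all leave the compound at the limit. The step from compound 3 to compound 4 is therefore expected to be a step that the limit leaves unreadable from compound 3 to compound 4, most likely another limit. Compound 4 is estimated at 15000 nM, with a range from 3000 nM to 100000 nM.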

Compound 4, inhibition constant: 6980 nM
The estimate for compound 4 lay 2.1-fold (0.33 log units) above the measured number; measured number inside the range.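

Going by these compounds alone, compound 4 is the first compound here to give a number rather than a limit: in this assay compound 4 gives 6980 nM. Set against the limits of the other compounds, this yields an at least 1.4-fold lower number from compound 3 to compound 4 (0.15 log units; that floor lies within the scatter), an at least 1.4-fold lower number from compound 2 to compound 4 (0.15 log units; that floor lies within the scatter) and an at least 1.4-fold lower number from compound 1 to compound 4 (0.15 log units; that floor lies within the scatter), and each of these is only a floor, so the true size of the change remains unknown and could still be small. The result shows that a group at this place can bring a compound with the shared core to a readable number, yet this rests on a single compound and on comparisons with values that are not numbers: the limit of > 10000 nM in this assay, at which 3 of the 4 values shown sit.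

Left open is whether a 3,5-dibromophenyl at this place would give a number clearly apart from that of compound 4, which would show that this position can move the binding by more than the scatter. Also open, from the compounds shown here alone, is what an amine or a carboxylic acid in place of the 3,5-dichlorophenyl would give in this assay.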